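Methoxy on the anilino ring across two azole cores

A few compounds are considered here, and "the series" means these few. Any claim that something is new, unique, unknown or untested is made for them only; others in the source may bear on it.

Compound 1 `COc1ccc(Nc2nc(-n3c(C)nc4ccccc43)cs2)cc1` gives 25 nM in a functional assay on RKO cells (Homo sapiens) for cytotoxicity, read by resazurin assay, with a stated time of 72 h; on this read-out lower numbers stand for stronger inhibition and higher numbers for weaker inhibition. Compound 2 `Cc1nccn1-c1csc(Nc2ccccc2)n1` gives 32500 nM in this assay, and compound 3 `Cc1nc2ccccc2n1-c1csc(Nc2ccccc2)n1` gives 40000 nM. The difference between the cores of compound 2 and compound 3 is not broken down here; their two values lie close together. Compound 4 `COc1cccc(Nc2nc(-n3ccnc3C)cs2)c1` is not yet measured. From compound 3 to compound 1 the change is methoxy in place of hydrogen on an aromatic carbon, and the step is a 1600-fold lower number from compound 3 to compound 1 (3.20 log units; beyond the scatter). From compound 2 to compound 4 the change is methoxy in place of hydrogen on an aromatic carbon; this is the same kind of change, not the same, since the place is meta to a large group where the earlier one was para to a large group, and the core also differs. Among the measured compounds shown here, for compound 4 a step of an 11-fold lower number from compound 2 to compound 4 (1.03 log units; beyond the scatter) is expected in this assay, smaller than a 1600-fold lower number from compound 3 to compound 1 (3.20 log units; beyond the scatter), because a 1600-fold lower number from compound 3 to compound 1 (3.20 log units; beyond the scatter) is the only step that supports it and the place of the change differs. Compound 4 is estimated at 3000 nM, between 300 nM and 30000 nM.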

Compound 4, half-maximal inhibitory concentration: 22500 nM
Estimate against measurement, compound 4: 7.5-fold (0.88 log units) below; the measured number falls inside the stated range.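

In this assay, the step on the core of compound 2, a 1.4-fold lower number from compound 2 to compound 4 (0.16 log units; within the scatter), shows no readable effect of methoxy placed meta to a large group. The size of the step therefore does not carry over between the two cores as these pairs stand: the same change on two cores in this assay, a 1600-fold lower number (3.20 log units; beyond the scatter) from compound 3 to compound 1 and a 1.4-fold lower number (0.16 log units; within the scatter) from compound 2 to compound 4, 1100-fold (3.04 log units) apart, beyond the scatter of two such steps

The two steps differ both in the core and in the place of the methoxy, and these data do not show which of the two accounts for the gap. Still open, on these data alone, are each core carrying methoxy at the place it holds on the other, which would separate the two differences. Also open, as far as these compounds go, is whether an amine or a longer alkoxy chain at either place would behave as methoxy does.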